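Dimethylamino to tert-butyl swap in the series

The compounds below may be only part of what the source reports. "The series", "measured", "known", "first", "only" and "open" are said of these compounds alone.

In a functional assay on KB 3-1 cells (Homo sapiens) for cytotoxicity, read by MTT assay, with a stated time of 72 h (on this read-out lower numbers stand for stronger inhibition and higher numbers for weaker inhibition), compound 1 (`O=C1Nc2ccccc2/C1=N/NC(=S)NC1CCCCC1`) gives 9140 nM and compound 2 (`O=C1Nc2ccccc2/C1=N/NC(=S)Nc1cc(F)c(F)c(F)c1`) gives 4410 nM while compound 3 (`CN(C)c1ccc(NC(=S)N/N=C2\C(=O)Nc3ccccc32)cc1`) gives 6950 nM and so sits within the scatter of both neighbours on the scale. Compound 4 (`CC(C)(C)c1ccc(NC(=S)N/N=C2\C(=O)Nc3ccccc32)cc1`) differs from compound 3 by tert-butyl in place of dimethylamino on an aromatic carbon. Within the data shown here, no measured pair differs in one place only, so no direct precedent exists for this change. In this assay no shift beyond the scatter is expected in either direction. The estimated 1.4-fold lower number from compound 3 to compound 4 (0.14 log units; within the scatter) stays within the scatter. Compound 4 is expected at 5000 nM (estimated range 2000 nM to 12000 nM).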

Compound 4, half-maximal inhibitory concentration: 8130 nM
Estimate against measurement, compound 4: 1.6-fold (0.21 log units) below, and the stated range covers the measured number.
By their numbers in this assay, from the lowest: compounds 2, 3, 4 and 1 (each within the scatter of the next, the first and the last beyond it).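

In this assay, among these compounds, the first single-place step, tert-butyl in place of dimethylamino on an aromatic carbon gives a 1.2-fold higher number from compound 3 to compound 4 (0.07 log units; within the scatter). At this position, para to a large group, the nitrogen of dimethylamino and its hydrogen-bond acceptor can therefore be replaced by an all-carbon group without a shift beyond the scatter. No supporting measurement bears on this step.

From the compounds shown here alone, whether a carboxylic acid or a primary amine at this position would move the number beyond the scatter stays open. So does whether this swap behaves alike on other aromatic substitution patterns.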